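The source may hold more compounds than are shown below. What is called first, only, known or untested is meant among the compounds shown, and "the series" means these compounds.

Of the compounds shown here, two of a shared core have been measured in a functional assay on UO-31 cells (Homo sapiens) for inhibition, read by sulforhodamine B assay, with a stated time of 48 h, tested at 10 uM; a higher number here means more inhibition at the concentration tested (going by the name of the read-out), a lower number less inhibition. Compound 1, with structure `Brc1cn2ccnc2c(-c2ccc3ncn(C4CCCCC4)c3c2)n1`, carries a bromo group on an aromatic carbon of that core; in this assay compound 1 gives 37.6%. Compound 2, with structure `c1cn2cc(-c3ccsc3)nc(-c3ccc4ncn(C5CCCCC5)c4c3)c2n1`, carries a thiophen-3-yl group at the same place; in this assay compound 2 gives 23.1%. For the measured compounds named here, the one step among the measured pair, a number 14.5 percentage points lower from compound 1 to compound 2 (beyond the scatter), shows that the change from a bromo group to a thiophen-3-yl group brought a modest loss. Going by the values given here, compound 2 therefore stands lowest of the two numbers, with compound 1 as its only neighbour.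

Compound 3, with structure `Clc1ccc(-c2cn3ccnc3c(-c3ccc4ncn(C5CCCCC5)c4c3)n2)cc1`, differs from compound 2 in one place: 4-chlorophenyl in place of thiophen-3-yl on an aromatic carbon. Among the compounds with values here, only the step from compound 1 to compound 2 bears on this, and it concerns a different pair of groups, so it offers limited guidance. Since both thiophen-3-yl and 4-chlorophenyl are aromatic rings at the same place, a step of about a number 4.9 percentage points higher from compound 2 to compound 3 (within the scatter) is expected, which lies within the scatter. For compound 3 the estimated inhibition in this assay is 28%, expected to fall between 10% and 50%.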

Compound 3, a percentage reported as inhibition, at one concentration (the size of the read-out at that concentration, not a potency): 36.1%
For compound 3 the middle estimate is 8.1 percentage points below the measured one, within the range that was stated.
By their numbers in this assay, from the lowest: compound 2; then compounds 3 and 1 (each within the scatter of the next).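

In this assay, putting 4-chlorophenyl in place of thiophen-3-yl on this aromatic carbon gives a clear change (a number 13 percentage points higher from compound 2 to compound 3 (beyond the scatter)), so two aromatic rings at the same place need not behave alike, something the first pair could not show. The comparison with the bromo compound adds the second half of the picture: 4-chlorophenyl in place of bromo leaves the reading essentially unchanged (a number 1.5 percentage points lower from compound 1 to compound 3 (within the scatter)), so the loss seen with thiophen-3-yl does not extend to every aromatic ring placed here. Nothing measured here explains why these two rings differ.

The compounds shown leave open whether the difference belongs to the chlorine or to the six-membered carbon ring itself, a question that a plain phenyl ring at this place could help separate. Also open is how an amine such as morpholine or a carboxylic acid would fare here, and with each reading taken at a single concentration, the potency of these compounds remains unknown.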